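The source may hold more compounds than are shown below. What is called first, only, known or untested is meant among the compounds shown, and "the series" means these compounds.

In a functional assay on BCG823 cells (Homo sapiens) for antiproliferative activity, read by MTT assay, with a stated time of 48 h (on this read-out higher numbers stand for weaker inhibition and lower numbers for stronger inhibition), compound 1 `O=c1cc(-c2ccccc2)oc2cc(OCc3ccccc3)c(OCCCN3CCCC3)c(O)c12` reads > 100000 nM, which is a limit of the assay and not a number. For the measured compounds named here, compound 2 `O=c1cc(-c2ccccc2)oc2cc(O)c(OCCCCN3CCCC3)c(O)c12` gives 86400 nM, the only true number so far, so there is no other measured number to rank it against. These two compounds differ in more than one place, so they show no effect of any single change.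

Compound 3 `O=c1cc(-c2ccccc2)oc2cc(OCc3ccccc3)c(OCCCCN3CCCC3)c(O)c12` arises from compound 2 through one change, benzyl in place of hydrogen on an oxygen on an aromatic ring, or hydroxy to benzyloxy. Going by the values given here, no measured step shows what this swap does on its own, so any expectation is rough. Compound 1 also carries a benzyloxy group, and its > 100000 nM is again a limit. In this assay the expected step is therefore no larger than the usual scatter, with no firm direction. For compound 3 the estimated value is 60000 nM, with an expected range of 15000 nM to 100000 nM. This estimate means an expected change a 1.4-fold lower number from compound 2 to compound 3 (0.16 log units; within the scatter).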

Compound 3, half-maximal inhibitory concentration: 3200 nM
Estimate against measurement, compound 3: 19-fold (1.27 log units) above; measured number outside the range, below it.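

In this assay, for the compounds shown here, benzyl in place of hydrogen on an oxygen on an aromatic ring gives a 27-fold lower number from compound 2 to compound 3 (1.43 log units; beyond the scatter), the first single change at this position whose size can be read. The benzyloxy group does not act alone, however: with benzyloxy present in both compounds, (pyrrolidin-1-yl)methyl in place of pyrrolidin-1-yl on a saturated chain carbon, three bonds along the chain from an oxygen on an aromatic ring, gives an at least 31-fold lower number from compound 1 to compound 3 (1.49 log units; beyond the scatter), so the chain carrying the pyrrolidine also matters on this read-out. Compound 1 stands at a limit of the assay and not at a number: the limit of > 100000 nM in this assay, at which 1 of the 3 values shown sits.

The compounds shown do not tell whether the gain belongs to the benzyl ring in particular or would also come with a smaller group on the same oxygen, such as methyl, or with a substituted benzyl, such as 4-chlorobenzyl. They also leave open how a longer chain, or a piperidine or morpholine in place of the pyrrolidine, would read alongside the benzyloxy group.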